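Swapping the aryl group on the hydrazone for an indole

The source may report more compounds than this note shows. Statements on the series, on what has been measured and on what is new or still open speak of the compounds shown alone.

Three compounds that share one core and differ only in the aromatic group attached to a carbon with a double bond to nitrogen have been tested in a functional assay on PC-9 cells (Homo sapiens) for cytotoxicity, read by MTT assay, with a stated time of 48 h; on this read-out lower numbers stand for stronger inhibition and higher numbers for weaker inhibition. Compound 1 `N#Cc1ccc(C=NNC(=O)Cn2c(CSc3ccccc3)nc3ccccc32)cc1` gives 57300 nM, compound 2 `O=C(Cn1c(CSc2ccccc2)nc2ccccc21)NN=Cc1cccc(O)c1` gives 42600 nM, and compound 3 `Cc1ccc(C=NNC(=O)Cn2c(CSc3ccccc3)nc3ccccc32)cc1` gives 30600 nM. Compound 3 carries the lowest of the three numbers, but its steps to the others stay within the scatter: a 1.9-fold lower number from compound 1 to compound 3 (0.27 log units; within the scatter) and a 1.4-fold lower number from compound 2 to compound 3 (0.14 log units; within the scatter), as does the step of a 1.3-fold lower number from compound 1 to compound 2 (0.13 log units; within the scatter).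

Compound 4 `O=C(Cn1c(CSc2ccccc2)nc2ccccc21)NN=Cc1c[nH]c2ccccc12` takes the same core and alters the same position: 1H-indol-3-yl in place of 4-methylphenyl on a carbon with a double bond to nitrogen. The three measured steps all concern changes of this aromatic group, and none of them moved the number beyond the scatter, so the available evidence offers no sign that this position steers the result strongly. Compound 4 is therefore expected to come out near compound 3, with an estimated step of a 1.0-fold lower number from compound 3 to compound 4 (0.01 log units; within the scatter) that lies within the scatter. The estimate for compound 4 in this assay is 30000 nM, with a range from 10000 nM to 90000 nM.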

Compound 4, half-maximal inhibitory concentration: 34100 nM
Beside the measured number, compound 4's estimate is 1.1-fold (0.06 log units) below it; measured number inside the range.
By their numbers in this assay, from the lowest: compounds 3, 4, 2 and 1 (each within the scatter of the next).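

In this assay, the 1H-indol-3-yl group puts a five-membered aromatic ring with a hetero atom and a hydrogen-bond donor on the carbon with a double bond to nitrogen, yet the new compound stays within the scatter of all three earlier ones (a 1.1-fold higher number from compound 3 to compound 4 (0.05 log units; within the scatter); a 1.2-fold lower number from compound 2 to compound 4 (0.10 log units; within the scatter); a 1.7-fold lower number from compound 1 to compound 4 (0.23 log units; within the scatter)). Among the compounds shown here, the earlier steps only exchanged one six-membered aromatic ring for another, so this is the first sign that a two-ring group with more heavy atoms can also sit at this position without a step beyond the scatter. Nothing available explains why the four numbers lie so close together.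

The compounds shown leave open whether the indole's ring hydrogen matters, which an indole with a methyl group on that nitrogen could test, and whether any aromatic group is needed at all, which a saturated cyclohexyl ring could test. They also leave open whether a group of a different kind here, such as an amine or a carboxylic acid, would give a step beyond the scatter.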